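One Aryl Exchange on the Ring Amine of Compound 3

The source may hold more compounds than are shown below. What is called first, only, known or untested is meant among the compounds shown, and "the series" means these compounds.

Of the compounds shown here, three have been measured in a functional assay on the whole organism (Abdomen, strain Swiss) for inhibition, with Mus musculus as the target, with stated times of 30 min, 10 min and 5 min, at a dose of 20 mg/kg by the oral route; a higher number here means a stronger effect of the compound at the dose given, a lower number a weaker effect. Compound 1, `CCCCC(=O)c1c(C)nn(CCCN2CCN(c3ccc(C)cc3)CC2)c(=O)c1N`, gives 23% in this assay. Compound 2, `C=Cc1c(CCCC)nn(CCCN2CCN(c3ccc(C)cc3)CC2)c(=O)c1N`, gives 41% in this assay. Compound 3, `Cc1c(C#N)c(-c2ccccc2)nn1CCCN1CCN(c2cccc(Cl)c2)CC1`, gives 0% in this assay, the lowest of the three numbers; compound 1 stands nearest to it, with a number higher by more than the usual scatter, and compound 2 stands furthest from it, again higher by more than the scatter. No two of the measured compounds differ in only one place, so none of these numbers can be read as the effect of a single change.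

Compound 4, `Cc1c(C#N)c(-c2ccccc2)nn1CCCN1CCN(c2ccc([N+](=O)[O-])cc2)CC1`, differs from compound 3 in one place: 4-nitrophenyl in place of 3-chlorophenyl on an amine nitrogen in a ring. Going by the values given here, no measured pair shows what this exchange does on this core, and nothing among compounds 1, 2 and 3 isolates a change on the amine nitrogen in the ring. With compound 3 at 0% in this assay, the step expected in this assay, a number 8 percentage points higher from compound 3 to compound 4 (within the scatter), is small and not beyond the scatter in either direction. Compound 4 is therefore estimated at 8% in this assay, within an expected range from 0% to 25%.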

Compound 4, a percentage reported as inhibition, in the whole organism at one dose (the size of the read-out at that dose, not a potency): 21%
For compound 4 the middle estimate is 13 percentage points below the measured one, and the stated range covers the measured number.
By their numbers in this assay, from the lowest: compound 3; then compounds 4 and 1 (each within the scatter of the next); then compound 2.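

On the core shared by compound 3 and compound 4, the aryl group on the amine nitrogen in the ring can now be read as a single change: in this assay, 4-nitrophenyl in place of 3-chlorophenyl gives a number 21 percentage points higher from compound 3 to compound 4 (beyond the scatter). Going by these compounds alone, the step is modest, but it shows that this position is not indifferent to the group it carries, since exchanging this aryl group alone moves the read-out beyond the scatter, something the earlier compounds, which differ from one another in more than one place, could not show. The exchange alters both the substituent on the phenyl ring and its place on that ring, so the step cannot be assigned to either alone, and nothing available here explains it.

Going by these compounds, it remains open whether the higher number follows the nitro group itself or would also appear with an unsubstituted phenyl, a methoxyphenyl or an aminophenyl on the same nitrogen. On these data alone, it is equally open whether this exchange would give a step of similar size on the core of compound 1 or of compound 2, both of which carry a different aryl group at this nitrogen.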